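Notes on the step from compound 3 to compound 4

The compounds below may be only part of what the source reports. "The series", "measured", "known", "first", "only" and "open" are said of these compounds alone.

Measured in a functional assay on LNCaP cells (Homo sapiens) for antiproliferative activity, read by WST assay, with a stated time of 3 days; on this read-out lower numbers stand for stronger inhibition and higher numbers for weaker inhibition:
- compound 1 `CCCCCCOc1c(-c2cc(OC)c(OC)c(OC)c2)oc2ccccc2c1=O` gives 19600 nM
- compound 2 `CCCC(C)Oc1c(-c2cc(OC)c(OC)c(OC)c2)oc2ccccc2c1=O` gives 15100 nM
- compound 3 `CCCN(CCC)CCCOc1c(-c2cc(OC)c(OC)c(OC)c2)oc2ccccc2c1=O` gives 17900 nM

Compound 3 stands level with the other two, since a 1.1-fold lower number from compound 1 to compound 3 (0.04 log units; within the scatter) and a 1.2-fold higher number from compound 2 to compound 3 (0.07 log units; within the scatter) both lie within the scatter. Within the data shown here, the remaining measured step, a 1.3-fold lower number from compound 1 to compound 2 (0.11 log units; within the scatter), is also within the scatter, so the series so far shows a single level.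

Compound 4 `CCCCCN(CCCCC)CCCCOc1c(-c2cc(OC)c(OC)c(OC)c2)oc2ccccc2c1=O` is the next to be read. Its change from compound 3 is (dipentylamino)methyl in place of dipropylamino on a saturated chain carbon, three bonds along the chain from an oxygen on an aromatic ring.

The closest measured change at that place is a 1.1-fold lower number from compound 1 to compound 3 (0.04 log units; within the scatter), where dipropylamino replaced propyl with no step beyond the scatter. The swap on the oxygen in a 1.2-fold higher number from compound 2 to compound 3 (0.07 log units; within the scatter) points the same way. Among the measured compounds shown here, no measured compound carries dipentylamino, so the data give no direct precedent, and the range is kept wide.

In this assay no step beyond the scatter is expected, and the expected step is a 1.3-fold lower number from compound 3 to compound 4 (0.11 log units; within the scatter) in size. For compound 4 the estimate is 14000 nM, with an expected range from 5500 nM to 30000 nM.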

Compound 4, half-maximal inhibitory concentration: 9700 nM
For compound 4 the middle estimate is 1.4-fold (0.16 log units) above the measured one; measured number inside the range.
By their numbers in this assay, from the lowest: compounds 4, 2, 3 and 1 (each within the scatter of the next, the first and the last beyond it).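

In this assay, among these compounds, the exchange of dipropylamino for (dipentylamino)methyl on a saturated chain carbon, three bonds along the chain from an oxygen on an aromatic ring, gives a 1.8-fold lower number from compound 3 to compound 4 (0.27 log units; within the scatter), so a group of 12 heavy atoms in place of one of 7 brings no step that can be told apart at this position. The series nevertheless no longer sits at a single level: with dipentylamino in place of ethyl on a saturated chain carbon, four bonds along the chain from an oxygen on an aromatic ring, there is a 2.0-fold lower number from compound 1 to compound 4 (0.31 log units; beyond the scatter), a modest step and the first one here beyond the scatter. No supporting measurement is at hand that bears on what lies behind this step.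

Going by these compounds, the exchange leading to compound 4 alters the chain and the groups on the nitrogen together, so the share of each in this modest step stays open. Also open, on these data alone, is how this assay responds to a ring amine such as piperidine, to a carboxylic acid at the end of the chain, or to a longer chain between the oxygen and the nitrogen.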